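The source may report more compounds than this note shows. Statements on the series, on what has been measured and on what is new or still open speak of the compounds shown alone.

Working notes on the thiourea-linked series.

In a functional assay on A549 cells (Homo sapiens) for antiproliferative activity, read by MTT assay, with a stated time of 72 h (a higher number here means a weaker inhibitor, a lower number a stronger inhibitor), compound 1 `NS(=O)(=O)c1ccc(NC(=S)Nc2ccc3ncnc(Nc4cccc(C(F)(F)F)c4)c3c2)cc1` gives 10100 nM. Compound 2 `NS(=O)(=O)c1ccc(NC(=S)Nc2ccc3ncnc(Nc4ccc(F)c(Br)c4)c3c2)cc1` reaches only the limit of this assay, > 40000 nM. Compound 3 `NS(=O)(=O)c1ccc(NC(=S)Nc2ccc3ncnc(Nc4cccc(Br)c4)c3c2)cc1` gives 25000 nM, which is the highest number among the compounds with a measured value. The remaining value, that of compound 2, is a limit (the limit of > 40000 nM in this assay, at which 1 of the 3 values shown sits). The steps among the measured compounds are an at least 3.9-fold higher number from compound 1 to compound 2 (0.59 log units; beyond the scatter), a 2.5-fold higher number from compound 1 to compound 3 (0.39 log units; beyond the scatter) and an at least 1.6-fold lower number from compound 2 to compound 3 (0.20 log units; that floor lies within the scatter); all of them involve changes on the aryl ring attached to the nitrogen on the aromatic core, and none is larger than modest.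

Compound 4 `Cc1ccc(Nc2ncnc3ccc(NC(=S)Nc4ccc(S(N)(=O)=O)cc4)cc23)cc1` differs from compound 3 in that (4-methylphenyl in place of 3-bromophenyl on a nitrogen on an aromatic ring). This change exchanges the whole substituted ring rather than a single substituent, so the measured steps bear on it only loosely; they suggest that such changes shift this assay by modest amounts in either direction. A small step, with no strong direction, is therefore expected: for compound 4 the expected step is a 1.2-fold higher number from compound 3 to compound 4 (0.08 log units; within the scatter). In this assay compound 4 is estimated at 30000 nM, with a range from 8000 nM to 100000 nM.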

Compound 4, half-maximal inhibitory concentration: 2840 nM
Compound 4: middle estimate off by 11-fold (1.02 log units), on the high side; measured number below the stated range.
By their numbers in this assay, from the lowest: compound 4; then compound 1; then compound 3. At a limit, above all of these: compound 2.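

Among the compounds shown here, the 4-methylphenyl ring gives the lowest number in this assay so far, with an 8.8-fold lower number from compound 3 to compound 4 (0.94 log units; beyond the scatter) and a 3.6-fold lower number from compound 1 to compound 4 (0.55 log units; beyond the scatter), so exchanging the ring on this nitrogen can move the number further than the differences among the earlier bromo and trifluoromethyl compounds showed. For the compounds shown here, the widest span is the floor of an at least 14-fold lower number from compound 2 to compound 4 (1.14 log units; beyond the scatter), the only step here graded large. The value of compound 2 is a limit, not a number: the limit of > 40000 nM in this assay, at which 1 of the 4 values shown sits.

Compound 4 differs from compound 3 in both the substituent and its place on the ring, so the shift cannot be assigned to the methyl group or to its location. Going by these compounds, how 3-methylphenyl, 4-bromophenyl, or a phenyl ring bearing an amine or a carboxylic acid would read in this assay remains open.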